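Swapping the Amine Substituent on a Chemokine Receptor Antagonist Core

This account rests on a few compounds, and the source may have more. Where it says the series, first, only, none or still open, it means among the compounds named here.

Compound 1, `CN(C[C@H]1Cc2c(cccc2N2CCC(N)CC2)CN1)[C@H]1CCCc2cccnc21`, gives 33.4 nM in a functional assay on CCRF-CEM cells for antagonist activity at C-X-C chemokine receptor type 4 (Homo sapiens), read by calcium flux, with stated times of 25 min and 90 s; on this read-out higher numbers stand for weaker inhibition and lower numbers for stronger inhibition.
Compound 2, `CN(C[C@H]1Cc2c(cccc2N2C[C@H]3CNC[C@H]3C2)CN1)[C@H]1CCCc2cccnc21`, gives 10.3 nM.
Compound 3, `CN(C)C1CCN(c2cccc3c2C[C@H](CN(C)[C@H]2CCCc4cccnc42)NC3)CC1`, gives 35.9 nM.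

Compound 3 has the highest number of the three, but a 1.1-fold higher number from compound 1 to compound 3 (0.03 log units; within the scatter) keeps it level with compound 1, while a 3.5-fold higher number from compound 2 to compound 3 (0.54 log units; beyond the scatter) sets it apart from compound 2. Compound 4, `CN(C[C@H]1Cc2c(cccc2N[C@H]2CC[C@H](N)CC2)CN1)[C@H]1CCCc2cccnc21`, differs from compound 3 in that ((4-aminocyclohexyl)amino in place of 4-(dimethylamino)piperidin-1-yl on an aromatic carbon). Going by the values given here, two measured steps bear on this: the exchange of the ring group on the aromatic carbon gave a 3.2-fold lower number from compound 1 to compound 2 (0.51 log units; beyond the scatter), and the change of amino to dimethylamino on a saturated ring carbon gave a 1.1-fold higher number from compound 1 to compound 3 (0.03 log units; within the scatter). A modest step at most is therefore expected, with no clear direction, so compound 4 is estimated at 30 nM, between 9 nM and 100 nM, meaning a 1.2-fold lower number from compound 3 to compound 4 (0.08 log units; within the scatter).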

Compound 4, half-maximal inhibitory concentration: 755 nM
For compound 4 the middle estimate is 25-fold (1.40 log units) below the measured one; measured number outside the range, above it.
By their numbers in this assay, from the lowest: compound 2; then compounds 1 and 3 (each within the scatter of the next); then compound 4.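

Putting (4-aminocyclohexyl)amino on the aromatic carbon produces a large step against each earlier group (a 21-fold higher number from compound 3 to compound 4 (1.32 log units; beyond the scatter)) (a 23-fold higher number from compound 1 to compound 4 (1.35 log units; beyond the scatter)) (a 73-fold higher number from compound 2 to compound 4 (1.87 log units; beyond the scatter)). The earlier compounds shown here, all with a nitrogen-containing ring at this position, showed only modest steps or none, so compound 4 shows that this position can respond far more strongly to a change of group. Nothing measured here explains the size of this step.

From the compounds shown here alone, it remains open whether the step follows the carbon-only ring or the amino link, which a piperidin-4-ylamino group could help separate. Going by these compounds, the effect of the other stereoisomer of the (4-aminocyclohexyl)amino group also remains open.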